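The source may report more compounds than this note shows. Statements on the series, on what has been measured and on what is new or still open speak of the compounds shown alone.

Measured so far in a functional assay on CHO cells for agonist activity at Free fatty acid receptor 1 (Homo sapiens), read by FLIPR and calcium flux, in the presence of a further agent that is not named here; a higher number here means that more compound is needed for the effect, a lower number that less compound is needed:
compound 1, `O=C(O)CCc1ccc(OCc2nc(-c3ccccc3Cl)no2)cc1`, gives 1200 nM
compound 2, `O=C(O)CCc1ccc(OCc2nc(-c3cccc(C(F)(F)F)c3)no2)cc1`, gives 1110 nM

On the numbers shown compound 2 stands at the low end of the two, but compound 1 lies within the usual scatter of it, so the pair cannot be ranked. Both share the same core and differ only in the substituent on the terminal aromatic ring, and that difference leaves no mark beyond repeat-measurement noise in this assay.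

Compound 3, `COc1cccc(-c2noc(COc3ccc(CCC(=O)O)cc3)n2)c1`, is the next member and has not yet been measured in this assay. Relative to compound 2 the change is methoxy in place of trifluoromethyl on an aromatic carbon. Within the data shown here, no pair of measured compounds differing in a single place is available, so no measured step guides this move; the only information is that the two substituent patterns seen so far give numbers within scatter of each other. The expected step is therefore a 1.4-fold higher number from compound 2 to compound 3 (0.13 log units; within the scatter), nothing beyond the scatter. For compound 3 the estimate in this assay is 1500 nM, with a range from 700 nM to 3500 nM.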

Compound 3, half-maximal effective concentration: 2670 nM
For compound 3 the middle estimate is 1.8-fold (0.25 log units) below the measured one, within the range that was stated.
By their numbers in this assay, from the lowest: compounds 2 and 1 (each within the scatter of the next); then compound 3.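

In this assay, methoxy in place of trifluoromethyl on an aromatic carbon, meta to a large group, gives a 2.4-fold higher number from compound 2 to compound 3 (0.38 log units; beyond the scatter), which shows that the number at this position can respond to the group it carries, something the pair of compound 1 and compound 2 did not reveal. The change of 2-chlorophenyl to 3-methoxyphenyl gives a 2.2-fold higher number from compound 1 to compound 3 (0.35 log units; beyond the scatter), a modest step as well, so compound 3 stands apart from both earlier compounds, though this step alters both the group and its place on the ring and cannot assign the shift to either alone. Nothing measured here accounts for the loss seen with methoxy.

From the compounds shown here alone, it remains open whether the step follows from the oxygen of methoxy or from the removal of trifluoromethyl, a question that a methyl, a hydroxyl or an ethoxy on the same aromatic carbon would help to settle. Going by these compounds, it is also open whether methoxy would give a similar number on the ring carbon that carries chlorine in compound 1, which would separate the effect of the group from that of its place.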